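The compounds below may be only part of what the source reports. "The series", "measured", "known", "first", "only" and "open" are said of these compounds alone.

For the measured compounds named here, in a functional assay on SW1573 cells (Homo sapiens) for antiproliferative activity, read by sulforhodamine B assay, with a stated time of 48 h (on this read-out lower numbers stand for stronger inhibition of growth and higher numbers for weaker inhibition of growth), compound 1 (`CCCCC(C#CC(=O)OC)O/C=C/C(=O)OC`) gives 240 nM and compound 2 (`CCC(C#CC(=O)OC)O/C=C/C(=O)OC`) gives 540 nM, the higher of the two numbers so far. In compound 3 (`CCCCCCC(C#CC(=O)OC)O/C=C/C(=O)OC`), butyl replaces hydrogen on a saturated chain carbon, three bonds along the chain from an oxygen on an unsaturated carbon and a triple-bonded carbon: butyl in place of hydrogen on a saturated chain carbon, three bonds along the chain from an oxygen on an unsaturated carbon and a triple-bonded carbon. Going by the values given here, one measured step bears on this carbon, the modest 2.3-fold higher number from compound 1 to compound 2 (0.35 log units; beyond the scatter), where hydrogen replaced ethyl. Read in reverse, it points to a lower number, though no data show how butyl compares with ethyl. The expected change is a 3.2-fold lower number from compound 2 to compound 3 (0.50 log units; beyond the scatter). Compound 3 is estimated at 170 nM, with an expected range of 60 nM to 450 nM.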

Compound 3, concentration for 50% growth inhibition: 3300 nM
Compound 3: the middle estimate sits 19-fold (1.29 log units) below what was measured, and the stated range ends below it.
By their numbers in this assay, from the lowest: compound 1; then compound 2; then compound 3.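

In this assay, lengthening the chain on this saturated chain carbon does not keep lowering the number: there is a 14-fold higher number from compound 1 to compound 3 (1.14 log units; beyond the scatter) and so compound 1 lies lowest, with both its shorter and longer neighbours higher. The full change from hydrogen to butyl gives a 6.1-fold higher number from compound 2 to compound 3 (0.79 log units; beyond the scatter) and so carries the longer chain of compound 3 past the shorter chain of compound 2, reversing the earlier trend. Nothing at hand explains this turn. Still open, on these data alone, is how a pentyl chain would fall, and exactly where the turn lies. Also open, as far as these compounds go, is whether a terminal amine or carboxylic acid on the hexyl chain would change the number.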